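Removing the 4-methoxyphenyl group from compound 1

A few compounds are considered here, and "the series" means these few. Any claim that something is new, unique, unknown or untested is made for them only; others in the source may bear on it.

Of the compounds shown here, three have numbers so far. Compound 1 (`COc1ccc(N2C(=O)COc3ccc(-c4ccc(O)cc4)cc32)cc1`) reads 16400 nM in a functional assay on HeLa cells (Homo sapiens) for antiproliferative activity, read by MTT assay, with a stated time of 72 h (on this read-out lower numbers stand for stronger inhibition and higher numbers for weaker inhibition), and holds the middle place among the three numbers. Compound 2 (`COc1ccc(N2C(=O)COc3ccc(-c4cnc(Cl)c(NS(=O)(=O)c5ccc(F)cc5)c4)cc32)cc1`) reads 8320 nM and compound 3 (`CC(C)N1C(=O)COc2ccc(-c3cccc(NS(=O)(=O)c4ccc(F)cc4)c3)cc21`) reads 22700 nM on the same scale. Neither of these two lies beyond the usual scatter from compound 1, so the potency of compound 1 is not set apart from either of them.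

The next compound, compound 4 (`O=C1COc2ccc(-c3ccc(O)cc3)cc2N1`), has not yet been measured. It differs from compound 1 in one place, with hydrogen in place of 4-methoxyphenyl on an amide-type nitrogen in a ring and the rest of the structure unchanged. Among the measured compounds shown here, all three measured compounds carry a group on this nitrogen and none has the amide hydrogen, so no measured pair shows what this change does. A modest move towards a higher number, meaning weaker inhibition, is expected, though a result within the scatter would not be surprising. The expected size is a 2.1-fold higher number from compound 1 to compound 4 (0.33 log units; beyond the scatter) in this assay as a rough estimate. For compound 4 the estimated value is 35000 nM with an expected span from 14000 nM to 90000 nM around it.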

Compound 4, half-maximal inhibitory concentration: > 40000 nM
Compound 4 was reported as a limit (the forecaster's own chance of this, stated with the estimate: 30%); at least 1.1-fold (0.05 log units) between middle value and limit.
By their numbers in this assay, from the lowest: compounds 2, 1 and 3 (each within the scatter of the next, the first and the last beyond it). At a limit, above all of these: compound 4.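

Among the compounds shown here, replacing the 4-methoxyphenyl group on the amide-type nitrogen with hydrogen gives an at least 2.4-fold higher number from compound 1 to compound 4 (0.38 log units; beyond the scatter) in this assay, the first step at this position that can be read, and it points towards weaker inhibition by more than the usual scatter. So the group on this nitrogen matters for the read-out in the core of compound 1, something that compounds 1, 2 and 3 could not show, since all of them carry a group there and no pair of them differs at this nitrogen alone. Compound 4 gives > 40000 nM, which is a limit of the assay and not a number, so the step fixes only a minimum size and how far the activity falls remains unknown: the limit of > 40000 nM in this assay, at which 1 of the 4 values shown sits.

The compounds shown leave open whether the 4-methoxyphenyl group itself is needed or whether a methyl group, a benzyl group, an unsubstituted phenyl ring or a longer chain such as n-butyl on this nitrogen would serve as well. They also leave open whether the same replacement would have a similar effect in compound 2, which carries the sulfonamide side chain.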